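Moving the chlorine: 2-chlorophenyl to 4-chlorophenyl

The source may hold more compounds than are shown below. What is called first, only, known or untested is meant among the compounds shown, and "the series" means these compounds.

In a functional assay on OVCAR-3 cells (Homo sapiens) for cytotoxicity, read by sulforhodamine B assay (a higher number here means a weaker inhibitor of growth, a lower number a stronger inhibitor of growth), compound 2 `CC1=CC[C@@H]([C@@](C)(O)CCCC(C)(C)NC(=S)N/N=C\c2ccccc2Cl)CC1` gives 42000 nM and is the higher of the two numbers, with compound 1 `CC1=CC[C@@H]([C@@](C)(O)CCCC(C)(C)NC(=S)N/N=C\c2ccc(C)cc2)CC1` at 6020 nM on the other side of the gap. Compound 3 `CC1=CC[C@@H]([C@@](C)(O)CCCC(C)(C)NC(=S)N/N=C\c2ccc(Cl)cc2)CC1` is unmeasured, and its difference from compound 2 is 4-chlorophenyl in place of 2-chlorophenyl on a carbon with a double bond to nitrogen in this single place. For the measured compounds named here, the only measured step bearing on this is a 7.0-fold higher number from compound 1 to compound 2 (0.84 log units; beyond the scatter) and it swaps 4-methylphenyl for 2-chlorophenyl, so it is only a partial guide. Expected in this assay is a 3.5-fold lower number from compound 2 to compound 3 (0.54 log units; beyond the scatter) as a lower number, no larger than that measured step. Compound 3 is estimated at 12000 nM with 4000 nM to 35000 nM as its expected range.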

Compound 3, concentration for 50% growth inhibition: 6660 nM
Estimate against measurement, compound 3: 1.8-fold (0.26 log units) above, within the range that was stated.
By their numbers in this assay, from the lowest: compounds 1 and 3 (each within the scatter of the next); then compound 2.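

Moving the chlorine alone separates the two chlorophenyl compounds in this assay (a 6.3-fold lower number from compound 2 to compound 3 (0.80 log units; beyond the scatter)), so the high number of compound 2 goes with 2-chlorophenyl and not with chlorine as such. With the substituent kept as in 4-methylphenyl, chloro in place of methyl stays within the scatter (a 1.1-fold higher number from compound 1 to compound 3 (0.04 log units; within the scatter)), so compound 1 and compound 3 cannot be ranked. Nothing measured here explains the gap between the two chlorophenyl groups. As far as these compounds go, whether 2-methylphenyl would carry the same penalty as 2-chlorophenyl remains open. Also open, from the compounds shown here alone, is whether a larger group such as 4-methoxyphenyl or an amine-bearing phenyl would keep the level of compound 3.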